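The source may hold more compounds than are shown below. What is called first, only, known or untested is meant among the compounds shown, and "the series" means these compounds.

Compound 1 `CCS(=O)(=O)Nc1cc(-c2ccc3ncnc(Nc4ccc(OC)cc4)c3c2)cnc1OC` gives 1610 nM in a functional assay on SK-HEP1 cells (Homo sapiens) for cytotoxicity, read by sulforhodamine B assay, with a stated time of 72 h; on this read-out lower numbers stand for stronger inhibition and higher numbers for weaker inhibition. Compound 2 `CCS(=O)(=O)Nc1cc(-c2ccc3ncnc(Nc4ccc(OC)c(OC)c4)c3c2)cnc1OC` gives 2840 nM. Compound 3 `CCS(=O)(=O)Nc1cc(-c2ccc3ncnc(Nc4ccc(OC)c(Cl)c4)c3c2)cnc1OC` gives 2810 nM.

Compound 3 stands among the other two numbers with no gap beyond the scatter: a 1.7-fold higher number from compound 1 to compound 3 (0.24 log units; within the scatter), a 1.0-fold lower number from compound 2 to compound 3 (0.00 log units; within the scatter), and for the remaining pair a 1.8-fold higher number from compound 1 to compound 2 (0.25 log units; within the scatter). Compound 4 `CCS(=O)(=O)Nc1cc(-c2ccc3ncnc(Nc4cccc(C(=O)OC)c4)c3c2)cnc1OC` brings (3-(methoxycarbonyl)phenyl in place of 3-chloro-4-methoxyphenyl on a nitrogen on an aromatic ring). Among the measured compounds shown here, none of the measured steps covers this exchange; they show only that a methoxy or a chloro on that phenyl ring moved this assay little. For the step to compound 4 no shift beyond the scatter is therefore expected, so a 1.1-fold lower number from compound 3 to compound 4 (0.05 log units; within the scatter) is the estimated step. In this assay compound 4 is expected to give 2500 nM, with a range of 900 nM to 7000 nM.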

Compound 4, half-maximal inhibitory concentration: 2400 nM
For compound 4 the middle estimate is 1.0-fold (0.02 log units) above the measured one, and the stated range covers the measured number.
By their numbers in this assay, from the lowest: compounds 1, 4, 3 and 2 (each within the scatter of the next).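

In this assay the exchange to 3-(methoxycarbonyl)phenyl on a nitrogen on an aromatic ring stays within the scatter whichever group leaves: a 1.2-fold lower number from compound 3 to compound 4 (0.07 log units; within the scatter) for 3-chloro-4-methoxyphenyl, a 1.2-fold lower number from compound 2 to compound 4 (0.07 log units; within the scatter) for 3,4-dimethoxyphenyl and a 1.5-fold higher number from compound 1 to compound 4 (0.17 log units; within the scatter) for 4-methoxyphenyl. The earlier compounds shown here varied only a methoxy or a chloro alongside a retained methoxy, whereas compound 4 carries a methoxycarbonyl group on the phenyl ring and no methoxy directly on it, still with no shift beyond the scatter.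

Going by these compounds, whether an amine or a carboxylic acid on this phenyl ring would give a shift beyond the scatter stays open. No measurement shown accounts for this flat response.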